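Working notes on compounds 1 to 4

A few compounds are considered here, and "the series" means these few. Any claim that something is new, unique, unknown or untested is made for them only; others in the source may bear on it.

Measured so far in a functional assay on HCT-116 cells (Homo sapiens) for inhibition, read by MTT assay, with a stated time of 48 h; a lower number here means a stronger inhibitor, a higher number a weaker inhibitor:
compound 1 `Clc1ccccc1CSc1nnc(-c2ccncc2)n1-c1ccccc1` gives 13900 nM
compound 2 `Brc1cccc(CSc2nnc(-c3ccncc3)n2-c2ccccc2)c1` gives 8170 nM
compound 3 `Fc1cccc(F)c1CSc1nnc(-c2ccncc2)n1-c1ccccc1` gives 22100 nM

Compound 2 has the lowest of the three numbers. Its nearest neighbour is compound 1, with a 1.7-fold lower number from compound 1 to compound 2 (0.23 log units; within the scatter); the gap to compound 3 is the only one beyond the scatter, a 2.7-fold higher number from compound 2 to compound 3 (0.43 log units; beyond the scatter), and it is modest. The third pair, a 1.6-fold higher number from compound 1 to compound 3 (0.20 log units; within the scatter), also stays within the scatter.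

Compound 4 `O=[N+]([O-])c1ccccc1CSc1nnc(-c2ccncc2)n1-c1ccccc1` differs from compound 2 in one place: 2-nitrophenyl in place of 3-bromophenyl on a saturated chain carbon bound to a sulfur. Going by the values given here, no measured step introduces a nitro group, so the bearing steps are only the three exchanges of substituted phenyl on the same chain carbon, and all of them are small: two within the scatter, one modest. On that basis a step in this assay from compound 2 to compound 4 of similar size is expected, most likely toward a somewhat higher number, since compound 2 already holds the lowest value and every exchange away from it has so far moved upward or not at all; the expected step is a 1.6-fold higher number from compound 2 to compound 4 (0.20 log units; within the scatter). For compound 4 the estimate is 13000 nM, with a range from 5000 nM to 32000 nM.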

Compound 4, half-maximal inhibitory concentration: > 50000 nM
Compound 4: no number, only a limit; the forecaster's own chance of this, stated with the estimate: 10%; middle value at least 3.8-fold (0.58 log units) from the limit.
By their numbers in this assay, from the lowest: compounds 2, 1 and 3 (each within the scatter of the next, the first and the last beyond it). At a limit, above all of these: compound 4.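

At the saturated chain carbon bound to a sulfur, the substituted phenyl group is not as freely exchanged as compounds 1 to 3 suggested: in this assay, 2-nitrophenyl in place of 3-bromophenyl gives an at least 6.1-fold higher number from compound 2 to compound 4 (0.78 log units; beyond the scatter). Going by these compounds alone, the change of nitro in place of chloro on an aromatic carbon gives an at least 3.5-fold higher number from compound 1 to compound 4 (0.55 log units; beyond the scatter), and 2-nitrophenyl in place of 2,6-difluorophenyl gives an at least 2.2-fold higher number from compound 3 to compound 4 (0.35 log units; beyond the scatter), so compound 4 is the weakest of the four, and nitro is the first change here to separate a compound from all the others beyond the scatter. Compound 4 stands at > 50000 nM, which is a limit of the assay and not a number, so these three steps fix only the smallest size each can have: the limit of > 50000 nM in this assay, at which 1 of the 4 values shown sits.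

From the compounds shown here alone, how far compound 4 lies past that limit stays open, and so does whether the drop belongs to nitro in particular or to other groups on that aromatic carbon. An amine, a methoxy group or a carboxylic acid in place of nitro would test this, as the compounds shown carry only chloro, bromo and fluoro for comparison.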